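Naphthalene for a Substituted Phenyl on the Benzylamine End

This account rests on a few compounds, and the source may have more. Where it says the series, first, only, none or still open, it means among the compounds named here.

In a functional assay on BXPC-3 cells (Homo sapiens) for inhibition, read by MTT assay, with a stated time of 72 h (on this read-out lower numbers stand for stronger inhibition of growth and higher numbers for weaker inhibition of growth), compound 1 `O=S(=O)(NCCCCNCc1ccc(Br)cc1)c1cc(C(F)(F)F)cc(C(F)(F)F)c1` gives 1700 nM, while compound 2 `O=S(=O)(NCCCNCc1ccc(Cl)c(C(F)(F)F)c1)c1cc(C(F)(F)F)cc(C(F)(F)F)c1` gives 7800 nM, the higher of the two numbers, and the gap between them lies beyond the usual scatter. Compound 3 `O=S(=O)(NCCCNCc1cccc2ccccc12)c1cc(C(F)(F)F)cc(C(F)(F)F)c1` differs from compound 2 in one place: naphthalen-1-yl in place of 4-chloro-3-(trifluoromethyl)phenyl on a saturated chain carbon bound to an amine nitrogen. Among the compounds with values here, no measured pair shows this change, so its effect is uncertain. A modest step toward a lower number is expected, a 2.0-fold lower number from compound 2 to compound 3 (0.29 log units; within the scatter), though it may stay within the scatter. In this assay compound 3 is estimated at 4000 nM, between 1500 nM and 11000 nM.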

Compound 3, concentration for 50% growth inhibition: 2700 nM
Compound 3: the middle estimate sits 1.5-fold (0.17 log units) above what was measured, within the range that was stated.
By their numbers in this assay, from the lowest: compounds 1 and 3 (each within the scatter of the next); then compound 2.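

Putting naphthalen-1-yl in place of 4-chloro-3-(trifluoromethyl)phenyl on a saturated chain carbon bound to an amine nitrogen gives, in this assay, a 2.9-fold lower number from compound 2 to compound 3 (0.46 log units; beyond the scatter). This first readable one-place change shows that the number responds to the group at this position, and that chlorine and fluorine in this group are not needed for the lower number. No measurement available here bears on the reason for this step. Still open, from the compounds shown here alone, is how an unsubstituted phenyl, a pyridine or naphthalen-2-yl would compare here. Also open, going by these compounds, is whether the step would hold on a longer chain.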